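Aminopyridazinyl Analogue of a Lipophilic Amide: Expected Lipophilicity

The source may hold more compounds than are shown below. What is called first, only, known or untested is meant among the compounds shown, and "the series" means these compounds.

compound 1 `Cc1cc(C)c(-c2c[nH]nc2C)cc1NC(=O)c1ccc(OCc2ccccn2)cc1`: > 3
compound 2 `Cc1cc(C)c(-c2cccc(N)n2)cc1NC(=O)c1ccc(OCc2ccccn2)cc1`: > 3

In a physicochemical assay for lipophilicity (a lower number here means a more polar compound, a higher number a more lipophilic compound), compound 1 gives > 3, which is a limit of the assay. In this assay compound 2 likewise gives only a limit, > 3. Within the data shown here, the single measured step, a step that the two limits leave unreadable from compound 1 to compound 2, is therefore not readable, as the limit of > 3 in this assay, at which 2 of the 2 values shown sit, shows. Compound 3 `Cc1cc(C)c(-c2ccc(N)nn2)cc1NC(=O)c1ccc(OCc2ccccn2)cc1` differs from compound 2 by 6-aminopyridazin-3-yl in place of 6-aminopyridin-2-yl on an aromatic carbon. Among the measured compounds shown here, no measured step covers this change, so the step expected as a number at least 0.20 log units lower from compound 2 to compound 3 (that floor lies within the scatter) rests on compound 2 alone and carries wide uncertainty. Compound 3 is estimated at 2.8, between 2.2 and 3.4, with a fair chance that only a limit is reported.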

Compound 3, distribution coefficient: 2.6
Compound 3: the middle estimate sits 0.20 log units above what was measured, and the stated range covers the measured number.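

Unlike the earlier compounds, compound 3 gives a number in this assay, 2.6, so a change at this aromatic carbon can now be seen to shift the read-out. 6-Aminopyridazin-3-yl in place of 6-aminopyridin-2-yl gives a number at least 0.40 log units lower from compound 2 to compound 3 (beyond the scatter), and in place of 3-methyl-1H-pyrazol-4-yl it gives a number at least 0.40 log units lower from compound 1 to compound 3 (beyond the scatter). Both steps are known only as floors, and the step between the two earlier compounds cannot be read, because those compounds sit at a limit: the limit of > 3 in this assay, at which 2 of the 3 values shown sit.

From the compounds shown here alone, the true size of both steps remains open. So does how a morpholine or a carboxylic acid would read at this position.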